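Compound 2 to compound 3: from amide to amine

The source may hold more compounds than are shown below. What is called first, only, known or untested is meant among the compounds shown, and "the series" means these compounds.

In a functional assay on SF-295 cells (Homo sapiens) for inhibition, read by sulforhodamine B assay, with a stated time of 48 h (on this read-out lower numbers stand for stronger inhibition of growth and higher numbers for weaker inhibition of growth), compound 1 `CCCCCCCCCCCC[C@@H](O)[C@H]1CC[C@H]([C@H](O)CCCCCCCCCCNC(=O)c2ccnn2C)O1` gives 10000 nM and compound 2 `CCCCCCCCCCCC[C@@H](O)[C@H]1CC[C@H]([C@H](O)CCCCCCCCCCN(C)C(=O)c2ccnn2C)O1` gives 2000 nM, the lower of the two numbers. Compound 3 `CCCCCCCCCCCC[C@@H](O)[C@H]1CC[C@H]([C@H](O)CCCCCCCCCCNCc2ccnn2C)O1` is not yet measured. It differs from compound 2 by ((1-methyl-1H-pyrazol-5-yl)methyl)amino in place of methyl((1-methyl-1H-pyrazol-5-yl)carbonyl)amino on a saturated chain carbon, ten or more bonds along the chain from an oxygen on a saturated carbon and a saturated ring carbon. In words, ((1-methyl-1H-pyrazol-5-yl)methyl)amino stands in place of methyl((1-methyl-1H-pyrazol-5-yl)carbonyl)amino on a saturated chain carbon.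

Within the data shown here, the only measured step bearing on this is a 5.0-fold lower number from compound 1 to compound 2 (0.70 log units; beyond the scatter), a modest change beyond the scatter, with methyl in place of hydrogen on an amide-type nitrogen. Among the measured compounds shown here, compound 3 has hydrogen on that nitrogen again, as compound 1 does, but it lacks the carbonyl, and no measured step covers that loss. The evidence is therefore partial, and a modest move to a higher number is expected, namely a 2.0-fold higher number from compound 2 to compound 3 (0.30 log units; within the scatter). For compound 3 the estimated value is 4000 nM, with an expected range of 1000 nM to 12000 nM.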

Compound 3, concentration for 50% growth inhibition: 1200 nM
For compound 3 the middle estimate is 3.3-fold (0.52 log units) above the measured one, and the stated range covers the measured number.
By their numbers in this assay, from the lowest: compounds 3 and 2 (each within the scatter of the next); then compound 1.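

In this assay, (1-methyl-1H-pyrazol-5-yl)methyl in place of (1-methyl-1H-pyrazol-5-yl)carbonyl on the amine nitrogen gives an 8.3-fold lower number from compound 1 to compound 3 (0.92 log units; beyond the scatter) with hydrogen kept on that nitrogen, so the carbonyl is not needed for growth inhibition at this position in the compounds shown. The change from the methylated amide to the secondary amine gives a 1.7-fold lower number from compound 2 to compound 3 (0.22 log units; within the scatter) and the two compounds are not told apart, so the amine without methyl matches the methylated amide on this read-out. No supporting measurement on these compounds accounts for either step.

Open, from the compounds shown here alone, is whether a tertiary amine with methyl on that nitrogen would move the number further from compound 3. Also open, going by these compounds, is whether a phenyl ring in place of the 1-methyl-1H-pyrazol-5-yl ring or a shorter chain would hold it.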